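Arylalkyne uracils: bromophenyl to benzyl swap on two cores

The compounds below may be only part of what the source reports. "The series", "measured", "known", "first", "only" and "open" are said of these compounds alone.

Measured compounds:
compound 1, `CC(=O)OCC(CCn1cc(C#Cc2ccc(Br)cc2)c(=O)n(C(=O)c2ccccc2)c1=O)COC(C)=O`, 47200 nM
compound 2, `CC(=O)OCC(CCn1cc(C#CCc2ccccc2)c(=O)n(C(=O)c2ccccc2)c1=O)COC(C)=O`, 29900 nM
compound 3, `O=c1[nH]c(=O)n(CCC(CO)CO)cc1C#Cc1ccc(Br)cc1`, 67700 nM

All three were tested in a functional assay on HeLa cells (Homo sapiens) for antiproliferative activity, read by MTT assay, with a stated time of 72 h; on this read-out higher numbers stand for weaker inhibition and lower numbers for stronger inhibition. Compound 1 gives 47200 nM and compound 2 gives 29900 nM; the two differ by benzyl in place of 4-bromophenyl on a triple-bonded carbon, and the step of a 1.6-fold lower number from compound 1 to compound 2 (0.20 log units; within the scatter) lies within the scatter. Compound 3 gives 67700 nM; it stands nearest to compound 1 within the scatter and furthest from compound 2, that gap being beyond the scatter. The difference between the core of compound 3 and the core of compound 1 is not broken down here.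

Compound 4, `O=c1[nH]c(=O)n(CCC(CO)CO)cc1C#CCc1ccccc1`, has not yet been measured. It differs from compound 3 by benzyl in place of 4-bromophenyl on a triple-bonded carbon, the same change that separates compound 2 from compound 1, seen twice in all among these compounds. Within the data shown here, since the only instance of this change so far, from compound 1 to compound 2, moved the number by a step within the scatter, a similar step is expected from compound 3 to compound 4 in this assay, namely a 1.6-fold lower number from compound 3 to compound 4 (0.21 log units; within the scatter), resting on the single pair compound 1 and compound 2. The number for compound 4 in this assay is therefore estimated at 42000 nM, with a range from 20000 nM to 90000 nM to allow for the repeat-to-repeat scatter and for the core not having been tested with this change before.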

Compound 4, half-maximal inhibitory concentration: 63800 nM
Compound 4: the middle estimate sits 1.5-fold (0.18 log units) below what was measured, and the stated range covers the measured number.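

In this assay, the swap of 4-bromophenyl for benzyl on the triple-bonded carbon gives a 1.1-fold lower number from compound 3 to compound 4 (0.03 log units; within the scatter), so on the core of compound 3, as on the core of compound 1, the step does not leave the scatter. Set side by side, the two steps cannot be told apart, and the swap reads alike on both cores: the same change on two cores in this assay, a 1.6-fold lower number (0.20 log units; within the scatter) from compound 1 to compound 2 and a 1.1-fold lower number (0.03 log units; within the scatter) from compound 3 to compound 4, 1.5-fold (0.17 log units) apart, within the scatter of two such steps. This supports treating 4-bromophenyl and benzyl as interchangeable at this place on these two cores in this assay, but it rests on just two pairs, and since neither step is distinguishable from repeat-to-repeat scatter, it does not show that a real effect of the swap carries from one core to the other, nor that the result holds on any third core.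

Still open, going by these compounds, is whether any group at this place moves the number beyond the scatter on either core, for example an amine, a carboxylic acid or a longer alkyl chain in place of benzyl. Also open is which of the differences between the core of compound 1 and the core of compound 3 matters, since the compounds shown do not separate them.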